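The compounds below may be only part of what the source reports. "The series", "measured", "known", "first", "only" and "open" are said of these compounds alone.

Working notes on the series. The shared core carries a pendant aryl group that varies: compound 1 `Cc1cc(-c2ccc3[nH]c(=O)nc(-c4ccccc4)c3c2)ccn1`, compound 2 `Cc1ccc(-c2ccc3[nH]c(=O)nc(-c4ccccc4)c3c2)cn1` and compound 3 `Cc1cncc(-c2ccc3[nH]c(=O)nc(-c4ccccc4)c3c2)c1`. In an ADME assay on THP-1 cells (Homo sapiens) for cytotoxicity, read by MTT assay, with a stated time of 72 h (a higher number here means that more compound is needed for the effect, a lower number that less compound is needed), compound 1 gives > 50000 nM, a limit of the assay rather than a number. Compound 2 gives > 50000 nM in this assay, likewise a limit. Compound 3 stands at > 50000 nM in this assay, again only a limit. Within the data shown here, the steps a step that the two limits leave unreadable from compound 1 to compound 2, a step that the two limits leave unreadable from compound 1 to compound 3 and a step that the two limits leave unreadable from compound 2 to compound 3 therefore cannot be sized, because the limit of > 50000 nM in this assay, at which 3 of the 3 values shown sit, holds every value so far.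

Compound 4 `O=c1nc(-c2ccccc2)c2cc(-c3ccc(F)cc3)ccc2[nH]1` is the next to be measured in this assay. Its change from compound 3 is 4-fluorophenyl in place of 5-methylpyridin-3-yl on an aromatic carbon. Among the measured compounds shown here, none of the measured steps is readable, so no direction can be taken from them; the only guidance is that every measured compound sits at the limit. Compound 4 is expected in this assay at 60000 nM, within 20000 nM to 200000 nM. The step that the limit leaves unreadable from compound 3 to compound 4 is accordingly estimated as none beyond the scatter, most likely another limit.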

Compound 4, half-maximal effective concentration: > 50000 nM
Compound 4 gave a limit, no number; the forecaster's own chance of this, stated with the estimate: 80%; the middle value lies beyond the limit too.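

In this assay compound 4 gives > 50000 nM, only a limit, so its steps from compound 1, compound 2 and compound 3 cannot be read: the limit of > 50000 nM in this assay, at which 4 of the 4 values shown sit. The compounds shown leave open whether any pendant aryl group on the shared core gives a measurable value in this assay.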